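The source may hold more compounds than are shown below. What is called first, only, known or untested is meant among the compounds shown, and "the series" means these compounds.

Compound 1 `CCCCCCCC/C=C\CCCCCCCCNCc1c(OC)cc(OC)cc1OC`: in an assay on microsomes from intestinal mucosa for inhibition of acyl-CoA:cholesterol acyltransferase (Oryctolagus cuniculus) (a higher number here means a weaker inhibitor, a lower number a stronger inhibitor), compound 1 gives > 100000 nM, which is a limit of the assay and not a number.
Compound 2 `CCCCCCCC/C=C\CCCCCCCCNC(=O)Nc1c(Cl)cc(Cl)cc1Cl`: in this assay compound 2 gives 1200 nM.

Going by the values given here, compound 2 therefore holds the only numerical value in this set; the other entry sits at the limit of > 100000 nM in this assay, at which 1 of the 2 values shown sits. Compound 3 `CCCCCCCC/C=C\CCCCCCCCNC(=O)Nc1c(CC)cccc1C(C)C` carries 2-ethyl-6-isopropylphenyl in place of 2,4,6-trichlorophenyl on an amide-type nitrogen. Among the compounds with values here, no step between measured compounds touches this change, so the expectation rests on compound 2 alone. Compound 3 is expected to be the stronger inhibitor, with an expected step of a 10-fold lower number from compound 2 to compound 3 (1.00 log units; beyond the scatter) in this assay that goes beyond the usual scatter. Compound 3 is estimated at 120 nM, between 25 nM and 600 nM.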

Compound 3, half-maximal inhibitory concentration: 37 nM
The estimate for compound 3 lay 3.2-fold (0.51 log units) above the measured number; measured number inside the range.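

In this assay, 2-ethyl-6-isopropylphenyl in place of 2,4,6-trichlorophenyl on the amide-type nitrogen gives a 32-fold lower number from compound 2 to compound 3 (1.51 log units; beyond the scatter). This position therefore responds strongly to the choice of aryl group, and in this pair chlorine is not needed for the stronger inhibition, since the group in compound 3 carries only carbon. No measurement shown here gives a property that accounts for this step.

This single pair cannot separate the part played by the ethyl group from that of the isopropyl group or the loss of the chlorines. On these data alone, how a 2,6-diisopropylphenyl group or a pyridine ring on that nitrogen would compare remains open.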